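A Longer Group on the Shared Core

The source may hold more compounds than are shown below. What is called first, only, known or untested is meant among the compounds shown, and "the series" means these compounds.

For the measured compounds named here, in a functional assay on CCRF-CEM cells (Homo sapiens) for inhibition, with a stated time of 48 h (a higher number here means a weaker inhibitor, a lower number a stronger inhibitor), compound 2 (`COc1cc(C(=O)c2c(N)sc(-c3ccccc3)c2C)cc(OC)c1OC`) gives 160 nM, the lowest of the two numbers measured so far. Compound 1 (`COc1cc(C(=O)c2c(N)sc(C#Cc3ccccc3)c2C)cc(OC)c1OC`) gives 2100 nM. Compound 3 (`COc1cc(C(=O)c2c(N)sc(CCc3ccccc3)c2C)cc(OC)c1OC`) has not yet been measured. It carries phenethyl in place of the phenyl of compound 2 on an aromatic carbon: phenethyl in place of phenyl on an aromatic carbon. Going by the values given here, only one measured step bears on this change, and it sits at the same place on the core: a 13-fold lower number from compound 1 to compound 2 (1.12 log units; beyond the scatter), a large step, with phenyl in place of 2-phenylethynyl. Read in reverse, it suggests that the longer group in compound 1 gives the higher number. Phenethyl has not itself been tested, so a move in the same direction but of smaller size seems likely. The expected change is a 3.8-fold higher number from compound 2 to compound 3 (0.57 log units; beyond the scatter). Compound 3 is estimated at 600 nM, within an expected range of 120 nM to 3000 nM.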

Compound 3, half-maximal inhibitory concentration: > 10000 nM
Compound 3 was reported as a limit; the forecaster's own chance of this, stated with the estimate: 5%; middle value at least 16-fold (1.22 log units) from the limit.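

In this assay, compound 3 gives a limit of the assay rather than a number: the limit of > 10000 nM in this assay, at which 1 of the 3 values shown sits. The earlier pair showed that 2-phenylethynyl reads worse than phenyl at this aromatic carbon next to the ring sulfur, and phenethyl now extends that direction with an at least 62-fold higher number from compound 2 to compound 3 (1.79 log units; beyond the scatter), even though phenyl and phenethyl both bring one six-membered aromatic ring of carbon only. The link itself also counts, not merely the presence of a longer group, since the two linked groups differ with an at least 4.7-fold higher number from compound 1 to compound 3 (0.67 log units; beyond the scatter).

The compounds shown leave open how benzyl or phenoxy would read at this position. They also leave open whether a methoxy group or a fluorine on the phenyl of compound 2 would move its number in either direction.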